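The source may hold more compounds than are shown below. What is called first, only, known or untested is meant among the compounds shown, and "the series" means these compounds.

- Compound 1 `Cc1ccnc2nc(-c3cccc(Cl)c3)cc(O)c12`: 100000 nM
- Compound 2 `Cc1cc(C)c2c(O)cc(-c3cccc(F)c3)nc2n1`: 2510 nM

In a functional assay on NSCLC cells (Homo sapiens) for inhibition (a higher number here means a weaker inhibitor of growth, a lower number a stronger inhibitor of growth), compound 2 stands at 2510 nM, the lower of the two numbers and beyond the scatter from compound 1. Compound 3 `Cc1cc(C)c2c(O)cc(-c3cccc(Cl)c3)nc2n1` differs from compound 2 by chloro in place of fluoro on an aromatic carbon, meta to a large group. For the measured compounds named here, no measured pair isolates this exchange, and compound 1 differs from compound 3 elsewhere, so its value cannot size it. The expected step, a 1.1-fold higher number from compound 2 to compound 3 (0.05 log units; within the scatter), is estimated to stay within the scatter, with no firm direction. For compound 3 the estimate is 2800 nM, with an expected range of 900 nM to 12000 nM.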

Compound 3, concentration for total growth inhibition: > 100000 nM
Compound 3: only a limit was reported; the forecaster's own chance of this, stated with the estimate: 10%; middle value at least 35-fold (1.55 log units) away from the limit.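

The exchange of fluoro for chloro on this aromatic carbon, meta to a large group, gives an at least 39-fold higher number from compound 2 to compound 3 (1.60 log units; beyond the scatter) in this assay, so the growth inhibition of compound 2 depends strongly on which halogen sits here. The entry for compound 3 is a limit, not a number: the limit of > 100000 nM in this assay, at which 1 of the 3 values shown sits. Methyl in place of hydrogen on an aromatic carbon gives a number no lower from compound 1 to compound 3 (the limit leaves the size open) in this assay, and the size of this step cannot be read. As far as these compounds go, what a methoxy group, an amine or a nitrile on this carbon would give stays open.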